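Thiazolidinone amides: step from compound 3 to compound 4

The source may hold more compounds than are shown below. What is called first, only, known or untested is meant among the compounds shown, and "the series" means these compounds.

Measured compounds in a functional assay on HOS-TE85 cells (Homo sapiens) for inhibition, read by CCK-8 assay, with a stated time of 72 h; on this read-out higher numbers stand for weaker inhibition and lower numbers for stronger inhibition:
- compound 1, `COc1ccc(F)cc1N1C(=O)CSC1c1cccc(C(=O)NCCCCn2cccn2)c1`, gives 97.3 nM
- compound 2, `Cc1ccnc(N2C(=O)CSC2c2cccc(C(=O)NCCCCn3cccn3)c2)c1`, gives 19.6 nM
- compound 3, `O=C(NCCCCn1cccn1)c1cccc(C2SCC(=O)N2c2ccncc2)c1`, gives only the assay limit > 1000 nM

Compound 3 stands at the weak end of the set: its value is a limit rather than a number, as noted in the limit of > 1000 nM in this assay, at which 1 of the 3 values shown sits. The steps that lead to it are both large: an at least 10-fold higher number from compound 1 to compound 3 (1.01 log units; beyond the scatter) and an at least 51-fold higher number from compound 2 to compound 3 (1.70 log units; beyond the scatter). Compound 2, the strongest measured member, differs from compound 1 as well: a 5.0-fold lower number from compound 1 to compound 2 (0.70 log units; beyond the scatter).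

Compound 4, `O=C(NCCCCn1cccn1)c1cccc(C2SCC(=O)N2c2cc(Cl)ccn2)c1`, is not yet measured. Its change from compound 3 is 4-chloropyridin-2-yl in place of pyridin-4-yl on an amide-type nitrogen in a ring. The closest measured comparison is compound 2, which carries 4-methylpyridin-2-yl on the same amide-type nitrogen in a ring and sits far below compound 3 in this assay. Reversing the large step from compound 2 to compound 3, with chlorine rather than methyl on the pyridin-2-yl, is therefore expected to give a strong fall in the number for compound 4, an at least 33-fold lower number from compound 3 to compound 4 (1.52 log units; beyond the scatter). The estimate for compound 4 in this assay is 30 nM, with a range from 8 nM to 150 nM.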

Compound 4, half-maximal inhibitory concentration: 36.4 nM
The estimate for compound 4 lay 1.2-fold (0.08 log units) below the measured number, and the stated range covers the measured number.
By their numbers in this assay, from the lowest: compounds 2 and 4 (each within the scatter of the next); then compound 1. At a limit, above all of these: compound 3.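

In this assay, going by these compounds alone, the value of compound 3 is a limit and not a number, and 4-chloropyridin-2-yl in place of pyridin-4-yl on the amide-type nitrogen in a ring gives an at least 27-fold lower number from compound 3 to compound 4 (1.43 log units; beyond the scatter), so compound 2 is no longer the only compound that separates from this limit: the limit of > 1000 nM in this assay, at which 1 of the 4 values shown sits. Chloro in place of methyl on an aromatic carbon leaves the read-out unresolved, with a 1.9-fold higher number from compound 2 to compound 4 (0.27 log units; within the scatter), so the two groups cannot be told apart in this assay and the low numbers at this place do not depend on the methyl group alone. The 5-fluoro-2-methoxyphenyl group also gives way to the new group, with a 2.7-fold lower number from compound 1 to compound 4 (0.43 log units; beyond the scatter), in the same direction as a 5.0-fold lower number from compound 1 to compound 2 (0.70 log units; beyond the scatter).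

Compound 3 differs from compounds 2 and 4 both in where the pyridine is attached and in carrying no further group, so the compounds shown cannot say which of the two changes carries the step. A plain pyridin-2-yl, and pyridin-2-yl groups bearing methoxy or trifluoromethyl in place of chloro, would separate these and show how far the tolerance for the group on the pyridine extends.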